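A Methoxy Added to the Fused Ring, Tested Twice

The compounds below may be only part of what the source reports. "The series", "measured", "known", "first", "only" and "open" are said of these compounds alone.

In an assay on membranes from liver for displacement of a labelled ligand from Sigma intracellular receptor 2 (Rattus norvegicus), read by scintillation counting, with a stated time of 120 min (on this read-out lower numbers stand for stronger inhibition and higher numbers for weaker inhibition), compound 1 `COc1cc2c(cc1OC)CN(CCCCCC(=O)c1c(C)c(OC)c(OC)c(OC)c1OC)CC2` gives 0.38 nM. Compound 2 `COc1cc2c(c(OC)c1OC)CN(CCCCCC(=O)c1c(C)c(OC)c(OC)c(OC)c1OC)CC2` carries one change, (methoxy in place of hydrogen on an aromatic carbon), and in this assay compound 2 gives 12.6 nM; the step is a 33-fold higher number from compound 1 to compound 2 (1.52 log units; beyond the scatter). Compound 3 `COc1cc2c(cc1OC)CN(CCCCCCC(=O)c1c(C)c(OC)c(OC)c(OC)c1OC)CC2` has a core whose difference from the core of compound 1 is not broken down here, and in this assay compound 3 gives 1.33 nM. Going by the values given here, compound 4 `COc1cc2c(c(OC)c1OC)CN(CCCCCCC(=O)c1c(C)c(OC)c(OC)c(OC)c1OC)CC2` is not yet measured; it differs from compound 3 by methoxy in place of hydrogen on an aromatic carbon, the same change at the same place as the one carried by compound 2. Because the earlier step was a 33-fold higher number from compound 1 to compound 2 (1.52 log units; beyond the scatter), a step of comparable size is expected, a 33-fold higher number from compound 3 to compound 4 (1.52 log units; beyond the scatter). On that basis compound 4 is expected to give 44 nM in this assay, estimated to lie between 15 nM and 130 nM.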

Compound 4, inhibition constant: > 1000 nM
Compound 4 ended at the assay's limit (the forecaster's own chance of this, stated with the estimate: 2%); at least 22-fold (1.35 log units) between middle value and limit.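

In this assay the new step is an at least 750-fold higher number from compound 3 to compound 4 (2.87 log units; beyond the scatter), and compound 4 stands at a limit of the assay rather than at a number: the limit of > 1000 nM in this assay, at which 1 of the 4 values shown sits. Methoxy in place of hydrogen on an aromatic carbon raises the number on both cores, but the size of the step does not carry over from one core to the other: the same change on two cores in this assay, a 33-fold higher number (1.52 log units; beyond the scatter) from compound 1 to compound 2 and an at least 750-fold higher number (2.87 log units; beyond the scatter) from compound 3 to compound 4, at least 22-fold (1.35 log units) apart, beyond the scatter of two such steps. This shows that the direction held on these two cores; it does not show the true size of the second step, why the steps differ, or any rule beyond these compounds.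

The compounds shown leave open how the same change behaves on a longer chain than that of compound 3. They also leave open whether ethoxy or fluorine in place of the methoxy would give a similar step.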